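A few compounds are considered here, and "the series" means these few. Any claim that something is new, unique, unknown or untested is made for them only; others in the source may bear on it.

Compound 3 `COc1ccc2c(c1)OC(c1cc(OC)c(OC)c(OC)c1)C(C(=O)OC(C)(C)C)=C2` gives 14100 nM in a functional assay for inhibition of nuclear factor NF-kappa-B complex (Homo sapiens); on this read-out lower numbers stand for stronger inhibition and higher numbers for weaker inhibition. It stands level with compound 2 `COc1ccc2c(c1)OC(c1cc(OC)c(OC)c(OC)c1)C(/C=N/O)=C2`, which gives 14100 nM; together they carry the highest numbers of the three measured. Compound 1 `COc1ccc2c(c1)OC(c1cc(OC)c(OC)c(OC)c1)C(C(=O)N(C)OC)=C2` gives 11700 nM and is the furthest away from compound 3. Compound 4 `CCNC(=O)C1=Cc2ccc(OC)cc2OC1c1cc(OC)c(OC)c(OC)c1` differs from compound 3 by ethylamino in place of tert-butoxy on a carbonyl carbon. Going by the values given here, all measured steps so far concern the group on the double-bonded ring carbon: a 1.2-fold higher number from compound 1 to compound 2 (0.08 log units; within the scatter), a 1.2-fold higher number from compound 1 to compound 3 (0.08 log units; within the scatter), and no change at the digits printed from compound 2 to compound 3 (within the scatter). None reaches beyond the scatter, so the swap at the carbonyl carbon toward compound 4 is expected to move this assay by no step beyond the scatter. The estimate for compound 4 is 13000 nM, in the range 5000 nM to 32000 nM. The expected step is a 1.1-fold lower number from compound 3 to compound 4 (0.04 log units; within the scatter).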

Compound 4, half-maximal inhibitory concentration: > 50000 nM
Compound 4 gave a limit, no number (the forecaster's own chance of this, stated with the estimate: 10%); at least 3.8-fold (0.58 log units) between middle value and limit.
By their numbers in this assay, from the lowest: compounds 1, 2 and 3 (each within the scatter of the next). At a limit, above all of these: compound 4.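

In this assay compound 4 gives > 50000 nM, a limit and not a number. Ethylamino is the first group at this place to go beyond the scatter, with an at least 3.5-fold higher number from compound 3 to compound 4 (0.54 log units; beyond the scatter), an at least 4.2-fold higher number from compound 1 to compound 4 (0.63 log units; beyond the scatter) and an at least 3.5-fold higher number from compound 2 to compound 4 (0.54 log units; beyond the scatter). The group on the carbonyl carbon therefore does matter for this read-out, although the groups of compounds 1, 2 and 3 stay within the scatter of one another.

From the compounds shown here alone, the true size of these steps stays open at a limit. Also open, going by these compounds, is whether dimethylamino, a longer chain on the amide nitrogen or a carboxylic acid would follow ethylamino or tert-butoxy.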